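Ring-nitrogen substituent: phenyl in place of pyridinylmethyl

This account rests on a few compounds, and the source may have more. Where it says the series, first, only, none or still open, it means among the compounds named here.

Compound 1 `CCOC(=O)c1ccc(-c2nn(C)c3ccccc23)cc1` carries a methyl group on the ring nitrogen of the shared core; in a functional assay on cells (Platelet, Homo sapiens) for inhibition (a higher number here means a weaker inhibitor, a lower number a stronger inhibitor), compound 1 gives 270 nM. Compound 2 `CCOC(=O)c1ccc(-c2nn(Cc3cccnc3)c3ccccc23)cc1` carries a (pyridin-3-yl)methyl group at the same position; in this assay compound 2 gives 5550 nM. Going by the values given here, the one measured step is a 21-fold higher number from compound 1 to compound 2 (1.31 log units; beyond the scatter). Compound 2 therefore stands with the highest number of the two measured compounds, its nearest neighbour being compound 1.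

Compound 3 `CCOC(=O)c1ccc(-c2nn(-c3ccccc3)c3ccccc23)cc1` is the next member. The change is phenyl in place of (pyridin-3-yl)methyl on an aromatic nitrogen. Among the compounds with values here, the only step that bears on it is a 21-fold higher number from compound 1 to compound 2 (1.31 log units; beyond the scatter), which shows that a large group on this nitrogen went with a much higher number. Phenyl is again a large group on the same nitrogen, though the pyridin-3-yl ring with its one acceptor and the saturated chain carbon both leave. Within the data shown here, no measured pair separates the part of the ring from that of the chain carbon. The expectation is a number below that of compound 2 and above that of compound 1, with wide uncertainty. Compound 3 is estimated at 1500 nM, within a range of 400 nM to 6000 nM. This corresponds to an expected step of a 3.7-fold lower number from compound 2 to compound 3 (0.57 log units; beyond the scatter).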

Compound 3, half-maximal inhibitory concentration: 2640 nM
Estimate against measurement, compound 3: 1.8-fold (0.25 log units) below, within the range that was stated.
By their numbers in this assay, from the lowest: compound 1; then compound 3; then compound 2.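

In this assay the ring carried directly on the aromatic nitrogen gives a 2.1-fold lower number from compound 2 to compound 3 (0.32 log units; beyond the scatter) and so recovers only a small part of the loss seen with the (pyridin-3-yl)methyl group. The comparison with the small group gives a 9.8-fold higher number from compound 1 to compound 3 (0.99 log units; beyond the scatter) and shows that the higher number does not depend on the saturated chain carbon or on the hetero atom of the pyridine ring, since phenyl has neither and still stands well above methyl. Across these three compounds, both large ring-bearing groups go with a higher number than methyl, and no measurement offered here explains this.

The step from compound 2 to compound 3 changes the chain carbon and the ring hetero atom together, so a benzyl group on the same nitrogen would be needed to separate the two. On these data alone, it also remains open whether the trend with size holds for the unsubstituted ring nitrogen, for an ethyl or longer alkyl chain, or for a pyridin-3-yl ring bound directly to the nitrogen.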